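Chloro for Methyl on a Shared Core

The source may hold more compounds than are shown below. What is called first, only, known or untested is meant among the compounds shown, and "the series" means these compounds.

Compound 2 `Cc1ccc(-c2noc3c2CCNCC3)cc1` shows the lowest of the two numbers recorded in a functional assay on HEK293 cells for antagonist activity at 5-hydroxytryptamine receptor 7 (Homo sapiens), read by luminescence and cAMP accumulation (on this read-out lower numbers stand for smaller maximal responses and higher numbers for larger maximal responses), where compound 2 gives 95.8%; its nearest neighbour, compound 1 `Fc1ccc(-c2noc3c2CCNCC3)cc1`, gives 98%. Within the data shown here, the single measured step, a number 2.2 percentage points lower from compound 1 to compound 2 (within the scatter), methyl in place of fluoro on an aromatic carbon, stayed within the scatter. Compound 3 `Clc1ccc(-c2noc3c2CCNCC3)cc1` differs from compound 2 by chloro in place of methyl on an aromatic carbon. Among the measured compounds shown here, because the only comparable change, a number 2.2 percentage points lower from compound 1 to compound 2 (within the scatter), produced nothing beyond the scatter, no step beyond it is expected here. Compound 3 is therefore estimated at 96%, within 88% to 103%. That expectation means a number 0.2 percentage points higher from compound 2 to compound 3 (within the scatter).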

Compound 3, largest response reached (reported as Imax), in percent of the reference or control that the assay uses: 94.9%
Beside the measured number, compound 3's estimate is 1.1 percentage points above it; measured number inside the range.
By their numbers in this assay, from the lowest: compounds 3, 2 and 1 (each within the scatter of the next).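

In this assay the change to chloro gives a number 0.9 percentage points lower from compound 2 to compound 3 (within the scatter) and a number 3.1 percentage points lower from compound 1 to compound 3 (within the scatter) and so adds a third group to this position, on an aromatic carbon para to a large group, with no step beyond the scatter. Fluoro, methyl and chloro therefore cannot be put in any order here, and the maximal response stays the same across these three compounds within the scatter. Nothing available explains this sameness. On these data alone, whether an amine, a carboxylic acid or a longer chain at this position would move the maximal response beyond the scatter stays open.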